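Swapping 2,4-dichlorobenzyl for 4-fluorobenzyl

A few compounds are considered here, and "the series" means these few. Any claim that something is new, unique, unknown or untested is made for them only; others in the source may bear on it.

Of the compounds shown here, three sharing one core have been tested in a functional assay on the whole organism with Rattus norvegicus as the target; a higher number here means that more compound is needed for the effect, a lower number that less compound is needed. Compound 1 `CCN(CCNC(=O)c1cc(Cl)c(N)cc1OC)Cc1ccccc1` gives 0.31 mg/kg, and compound 2 `CCN(CCNC(=O)c1cc(Cl)c(N)cc1OC)Cc1ccc(OC)cc1` gives 0.2 mg/kg. Compound 3 `CCN(CCNC(=O)c1cc(Cl)c(N)cc1OC)Cc1ccc(Cl)cc1Cl` gives 10 mg/kg, the highest number of the three, so it needs the most compound for the effect.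

The unmeasured compound 4 `CCN(CCNC(=O)c1cc(Cl)c(N)cc1OC)Cc1ccc(F)cc1` differs from compound 3 in one group: 4-fluorophenyl in place of 2,4-dichlorophenyl on a saturated chain carbon bound to an amine nitrogen. In other words, 4-fluorophenyl stands in place of 2,4-dichlorophenyl on a saturated chain carbon bound to an amine nitrogen.

Two measured steps change this same group: a 32-fold higher number from compound 1 to compound 3 (1.51 log units; beyond the scatter) and a 50-fold higher number from compound 2 to compound 3 (1.70 log units; beyond the scatter). Both are large, and both lead to the 2,4-dichlorophenyl group. The third step, a 1.6-fold lower number from compound 1 to compound 2 (0.19 log units; within the scatter), shows that compounds 1 and 2 sit close together. Losing the 2,4-dichlorophenyl group should therefore bring the number down sharply, towards those two compounds. The expected step in this assay is a 25-fold lower number from compound 3 to compound 4 (1.40 log units; beyond the scatter).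

Among the compounds with values here, no fluorine-bearing compound has been measured, so the range stays wide. For compound 4 the estimated value is 0.4 mg/kg, with an expected range from 0.12 mg/kg to 2 mg/kg.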

Compound 4, dose for half-maximal effect: 0.2 mg/kg
For compound 4 the middle estimate is 2.0-fold (0.30 log units) above the measured one, and the stated range covers the measured number.
By their numbers in this assay, from the lowest: compounds 2, 4 and 1 (each within the scatter of the next); then compound 3.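

The step in this assay is large (a 50-fold lower number from compound 3 to compound 4 (1.70 log units; beyond the scatter)), so a halogen on this aromatic ring does not by itself raise the number; among these compounds only the 2,4-dichlorophenyl group does. Compound 4 also sits with the two earlier low compounds (no change at the digits printed from compound 2 to compound 4 (within the scatter); a 1.6-fold lower number from compound 1 to compound 4 (0.19 log units; within the scatter)), which means that hydrogen, methoxy and fluoro on this aromatic carbon all give numbers within the scatter of one another. Nothing available here gives a reason for the large gap to compound 3.

The compounds shown leave open which chlorine of the 2,4-dichlorophenyl group goes with the high number, a question that 4-chlorophenyl and 2-chlorophenyl would separate. Also open, as far as these compounds go, is whether this assay would give a similar number with an amine or a nitrile on the ring.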